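The source may hold more compounds than are shown below. What is called first, only, known or untested is meant among the compounds shown, and "the series" means these compounds.

Measured compounds:
compound 1, `CCCCN(C)c1nc(C(C)(C)C)ccc1CNC(=O)C(C)c1ccc(NS(C)(=O)=O)c(F)c1`: 1.2 nM
compound 2, `CCCN(CCC)c1nc(C(C)(C)C)ccc1CNC(=O)C(C)c1ccc(NS(C)(=O)=O)c(F)c1`: 2.5 nM
compound 3, `COCCCOc1nc(C(C)(C)C)ccc1CNC(=O)C(C)c1ccc(NS(C)(=O)=O)c(F)c1`: 5.6 nM

In an assay on cells for antagonist activity at transient receptor potential cation channel subfamily V member 1 (Homo sapiens), read by FLIPR and calcium flux, with a stated time of 6 min (on this read-out lower numbers stand for stronger inhibition and higher numbers for weaker inhibition), compound 3 gives the highest of the three numbers; the steps of a 4.7-fold higher number from compound 1 to compound 3 (0.67 log units; beyond the scatter) and a 2.2-fold higher number from compound 2 to compound 3 (0.35 log units; beyond the scatter) set it beyond the scatter from both others. Compound 4, `CCCCCCSc1nc(C(C)(C)C)ccc1CNC(=O)C(C)c1ccc(NS(C)(=O)=O)c(F)c1`, has not yet been measured. It differs from compound 3 by hexylsulfanyl in place of 3-methoxypropoxy on an aromatic carbon. For the measured compounds named here, the steps of a 4.7-fold higher number from compound 1 to compound 3 (0.67 log units; beyond the scatter) and a 2.2-fold higher number from compound 2 to compound 3 (0.35 log units; beyond the scatter) show that exchanging the group at this aromatic carbon moves the number by modest amounts, so a modest step in this assay is expected here, though its direction is uncertain, since no measured pair contains a hexylsulfanyl group. Compound 4 is therefore estimated at about 5 nM, within 1.5 nM to 20 nM, which amounts to an expected step of a 1.1-fold lower number from compound 3 to compound 4 (0.05 log units; within the scatter).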

Compound 4, inhibition constant: 1.5 nM
The estimate for compound 4 lay 3.3-fold (0.52 log units) above the measured number; the range from low to high includes it.
By their numbers in this assay, from the lowest: compounds 1, 4 and 2 (each within the scatter of the next, the first and the last beyond it); then compound 3.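

In this assay, the step of a 3.7-fold lower number from compound 3 to compound 4 (0.57 log units; beyond the scatter) shows that a chain on this aromatic carbon next to the ring nitrogen need not be joined through nitrogen to stand apart from 3-methoxypropoxy. The steps of a 1.7-fold lower number from compound 2 to compound 4 (0.22 log units; within the scatter) and a 1.3-fold higher number from compound 1 to compound 4 (0.10 log units; within the scatter) lie within the scatter, so hexylsulfanyl cannot be told apart from either amino group here. Nothing given bears on why these groups differ.

The compounds shown leave open whether the step from 3-methoxypropoxy comes from the linking sulfur or from the chain itself. A hexyloxy group or a 3-methoxypropylsulfanyl group would separate the two.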